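A few compounds are considered here, and "the series" means these few. Any claim that something is new, unique, unknown or untested is made for them only; others in the source may bear on it.

Compound 1, `C/C(=C\COC(=O)Nc1ccccc1)C1=CC(=O)C(C)(C)O1`, in a functional assay on L1210 cells (Mus musculus) for inhibition (on this read-out higher numbers stand for weaker inhibition and lower numbers for stronger inhibition), gives only a limit of the assay, > 200 ug/mL. Compound 2, `C/C(=C\COC(=O)NC(C)C)C1=CC(=O)C(C)(C)O1`, in this assay gives 4.9 ug/mL. Compound 3, `COc1ccc(/C=C/C=C(\C)C2=CC(=O)C(C)(C)O2)cc1`, in this assay gives 18 ug/mL.

Compound 3 holds the highest of the two numbers shown; the nearest is compound 2, which lies lower by a gap beyond the scatter. Compound 1 sits at the limit of > 200 ug/mL in this assay, at which 1 of the 3 values shown sits.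

Compound 4, `C/C(=C\C=C\c1ccccc1)C1=CC(=O)C(C)(C)O1`, differs from compound 3 by hydrogen in place of methoxy on an aromatic carbon. Among the measured compounds shown here, the only measured step, an at least 40-fold lower number from compound 1 to compound 2 (1.61 log units; beyond the scatter), concerns the group on an amide-type nitrogen, a different part of the molecule, and does not bear on this change. For the measured compounds named here, no measured step touches the aromatic ring, so in this assay the expected step is none beyond the scatter, estimated as a 1.1-fold higher number from compound 3 to compound 4 (0.05 log units; within the scatter). Compound 4 is therefore expected to give about 20 ug/mL, estimated within a range from 7 ug/mL to 60 ug/mL.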

Compound 4, half-maximal inhibitory concentration: 14 ug/mL
Estimate against measurement, compound 4: 1.4-fold (0.15 log units) above; measured number inside the range.
By their numbers in this assay, from the lowest: compound 2; then compounds 4 and 3 (each within the scatter of the next). At a limit, above all of these: compound 1.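

Replacing the methoxy with hydrogen on the six-membered aromatic ring, para to a large group, gives a 1.3-fold lower number from compound 3 to compound 4 (0.11 log units; within the scatter) in this assay. Among the compounds shown here, this is the first measured change on this ring, and it shows that at this position the methoxy can give way to hydrogen with no change beyond the scatter. Nothing in the data shown accounts for this result. As far as these compounds go, whether an amine or a carboxylic acid at the same position would behave in the same way remains open. So does the effect of a longer chain, such as ethoxy.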